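The compounds below may be only part of what the source reports. "The series", "measured", "known", "first", "only" and "open" are said of these compounds alone.

Working notes on the series. In a functional assay on the whole organism (Central nervous system) for activation, with Mus musculus as the target (a lower number here means that less compound is needed, a higher number that more compound is needed for the effect), compound 1 `O=C(CCC(=O)c1ccc(Cl)cc1)NCCCO` gives 300 mg/kg. Compound 2 `Cc1ccc(C(=O)CCC(=O)NCCCO)c(C)c1` gives 150 mg/kg in this assay. Within the data shown here, compound 2 stands at the lower of the two numbers, with compound 1 as its only neighbour; the gap between them is within the scatter, so no order of the two can be stated from it. Among the measured compounds shown here, no step between two measured compounds that differ in a single place is available in this set.

Compound 3 `Cc1ccc(C(=O)CCC(=O)NCCCO)cc1` is not yet measured in this assay. Compared with compound 2, the change is hydrogen in place of methyl on an aromatic carbon. The shared core, the chain and the amide end are kept. For the measured compounds named here, with no single-site step among the measured compounds to lean on, the size of this change cannot be read from the data; the two measured compounds, compound 1 at 300 mg/kg and compound 2 at 150 mg/kg, differ at the aromatic ring and still sit within the scatter of each other. The expected step is a 1.3-fold higher number from compound 2 to compound 3 (0.12 log units; within the scatter), that is, nothing clearly beyond the scatter, if anything toward a somewhat higher number. Compound 3 is estimated at 200 mg/kg in this assay, with a range from 100 mg/kg to 400 mg/kg.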

Compound 3, dose for half-maximal effect: 300 mg/kg
Estimate against measurement, compound 3: 1.5-fold (0.18 log units) below; the measured number falls inside the stated range.
By their numbers in this assay, from the lowest: compounds 2, 1 and 3 (each within the scatter of the next).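

In this assay, among these compounds, the step of a 2.0-fold higher number from compound 2 to compound 3 (0.30 log units; within the scatter) gives the first reading at a single site: hydrogen in place of methyl on an aromatic carbon ortho to a large group leaves the two compounds within the scatter of each other, so no order can be stated and this methyl group has no effect that can be resolved here. The second single-site step, methyl in place of chloro on an aromatic carbon, reads no change at the digits printed from compound 1 to compound 3 (within the scatter), so at this level of resolution that exchange also separates nothing on the ring. Nothing further in the data accounts for how small these two steps are.

Going by these compounds, whether any substituent on this ring can give a step beyond the scatter in this assay remains open, for instance a methoxy group, a trifluoromethyl group or an amine on the same aromatic carbon. Also open, on these data alone, is whether the chain and the amide end matter more than the ring, as a longer chain or a carboxylic acid in place of the terminal hydroxyl would show.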